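A few compounds are considered here, and "the series" means these few. Any claim that something is new, unique, unknown or untested is made for them only; others in the source may bear on it.

Compound 1 `Cc1cn(-c2cc(NC(=O)Nc3ccc(C4=Nc5cnn(Cc6ccccc6)c5NC(=O)C4)cc3)cc(C(F)(F)F)c2)cn1`: > 30000 nM
Compound 2 `COc1ccc(Cn2ncc3c2NC(=O)CC(c2cccc(NC(=O)Nc4cccc(Cl)c4)c2)=N3)cc1`: 630 nM

Both compounds were tested in a functional assay on U-937 cells (Homo sapiens) for inhibition, read by MTT assay, with a stated time of 24 h; on this read-out higher numbers stand for weaker inhibition of growth and lower numbers for stronger inhibition of growth. For compound 1 the result is only a limit of the assay, > 30000 nM, not a measured number; this is the limit of > 30000 nM in this assay, at which 1 of the 2 values shown sits. Among the compounds with values here, compound 2 gives 630 nM in this assay, the only real number in hand, so it stands alone, with nothing to compare it to.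

Compound 3 `COc1ccc(Cn2ncc3c2NC(=O)CC(c2cccc(NC(=O)Nc4ccc(Cl)c(Cl)c4)c2)=N3)cc1` has not yet been measured. It differs from compound 2 in a single place: chloro in place of hydrogen on an aromatic carbon. Within the data shown here, no step between two measured compounds shows what a change of this kind does here, so the expectation rests on the change alone, which is small and keeps everything else in the molecule as it is. The expected step from compound 2 to compound 3 is a 1.6-fold lower number from compound 2 to compound 3 (0.20 log units; within the scatter), a modest change that may well fall within the ordinary scatter. Compound 3 is therefore estimated at 400 nM in this assay, with a range from 120 nM to 1600 nM.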

Compound 3, concentration for 50% growth inhibition: 14900 nM
The estimate for compound 3 lay 37-fold (1.57 log units) below the measured number; measured number outside the range, above it.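

In this assay, adding one chloro to turn the 3-chlorophenyl group into a 3,4-dichlorophenyl group gives a 24-fold higher number from compound 2 to compound 3 (1.37 log units; beyond the scatter), which means much weaker inhibition of growth. Within the data shown here, this is the first direct reading of this position, on an aromatic carbon para to a large group and ortho to a chloro group, and it shows that the result here is highly sensitive to a change of just 1 heavy atom, while compound 3 still gives a real number and not a limit of the assay. Nothing in hand shows why this one chloro has so large an effect.

Going by these compounds, what remains open is whether any group at this place would do the same, or whether the outcome is particular to chloro, as an amine, a methoxy group or a carboxylic acid here could show. Among these compounds, it is also open whether the step depends on the chloro already present on the ring, and whether it would hold on a different core, since this is the only pair that differs in one place and compound 1 differs from both compounds in several.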